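The source may report more compounds than this note shows. Statements on the series, on what has been measured and on what is new or still open speak of the compounds shown alone.

Compound 1 `Cc1ccc(-c2nnc(SCCCN3CCN(c4nc5ccccc5o4)CC3)o2)cc1`: 154000 nM
Compound 2 `COc1ccc(-c2nnc(SCCCN3CCN(c4nc5ccccc5s4)CC3)o2)cc1`: 134000 nM

Both compounds were tested in a functional assay on HepG2 cells (Homo sapiens) for inhibition, read by MTT assay, with a stated time of 72 h; on this read-out lower numbers stand for stronger inhibition and higher numbers for weaker inhibition. For the measured compounds named here, the number for compound 2 lies within the usual scatter of the number for compound 1, so the two cannot be told apart and compound 2 does not stand clear of its only measured neighbour.

The next compound is compound 3 `Cc1ccc(-c2nnc(SCCCN3CCN(c4nc5ccccc5s4)CC3)o2)cc1`. It is compound 2 with methyl in place of methoxy on an aromatic carbon, para to a large group, which turns 4-methoxyphenyl into 4-methylphenyl: methyl in place of methoxy on an aromatic carbon. Going by the values given here, no measured pair isolates this change, so the data give no direct size for it. Among the compounds with values here, the only indirect hint is compound 1, which carries the 4-methylphenyl group but also differs from compound 2 elsewhere. Compound 1 gives 154000 nM. That number sits within the scatter of the number for compound 2, so no step beyond the scatter is expected in this assay. The estimated change is a 1.0-fold higher number from compound 2 to compound 3 (0.02 log units; within the scatter). For compound 3 the expected value is 140000 nM, with an estimated range from 70000 nM to 280000 nM.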

Compound 3, half-maximal inhibitory concentration: 96700 nM
Compound 3: middle estimate off by 1.4-fold (0.16 log units), on the high side; the range from low to high includes it.
By their numbers in this assay, from the lowest: compounds 3, 2 and 1 (each within the scatter of the next).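

For the compounds shown here, compound 3 provides the first pairs in this set that differ in one place, so the size of each change can now be read in this assay directly. Methyl in place of methoxy on an aromatic carbon, para to a large group, gives a 1.4-fold lower number from compound 2 to compound 3 (0.14 log units; within the scatter) and therefore does not carry the result beyond the usual scatter at this position. 1,3-Benzothiazol-2-yl in place of 1,3-benzoxazol-2-yl on an amine nitrogen in a ring gives a 1.6-fold lower number from compound 1 to compound 3 (0.20 log units; within the scatter) and likewise stays inside the scatter, so neither change separates the three compounds on this read-out. Nothing measured here offers an explanation for either step.

The compounds shown leave open whether a chlorine, an amine or a carboxylic acid on that same aromatic carbon would produce a step beyond the scatter. They also leave open whether a longer chain in place of the one shared by all three compounds would move the number any more clearly than these two changes do.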